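The compounds below may be only part of what the source reports. "The series", "measured", "known", "first", "only" and "open" are said of these compounds alone.

Of the compounds shown here, two have so far been measured in an assay for inhibition of Polyunsaturated fatty acid 5-lipoxygenase (Homo sapiens), read by HPLC, with a stated time of 10 min; a lower number here means a stronger inhibitor, a higher number a weaker inhibitor. Compound 1 `CCC(Sc1nc(Cl)cc(Nc2nc(-c3ccc(Cl)cc3)cs2)n1)C(=O)O` gives 6600 nM, while compound 2 `CCCCCCC(Sc1nc(Cl)cc(Nc2nc(-c3cccc4ccccc34)cs2)n1)C(=O)O` gives 700 nM, the lower of the two numbers, and the gap between them lies beyond the usual scatter. Compound 3 `CCCCCCC(Sc1nc(Cl)cc(Nc2nc(-c3ccc(-c4ccccc4)cc3)cs2)n1)C(=O)O` has not yet been measured in this assay; it differs from compound 2 by 4-phenylphenyl in place of naphthalen-1-yl on an aromatic carbon. Among the compounds with values here, no step of this kind has been measured here, so only a small change is expected, a 1.3-fold higher number from compound 2 to compound 3 (0.11 log units; within the scatter), probably within the scatter. Compound 3 is therefore estimated at about 900 nM in this assay, with a range from 300 nM to 3000 nM.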

Compound 3, half-maximal inhibitory concentration: 600 nM
Compound 3: the middle estimate sits 1.5-fold (0.18 log units) above what was measured, within the range that was stated.
By their numbers in this assay, from the lowest: compounds 3 and 2 (each within the scatter of the next); then compound 1.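

Putting 4-phenylphenyl in place of naphthalen-1-yl gives a 1.2-fold lower number from compound 2 to compound 3 (0.07 log units; within the scatter) in this assay. This first single-place comparison shows that, on this aromatic carbon next to the ring nitrogen, these two groups, each with 2 six-membered aromatic rings of carbon only, cannot be told apart. Nothing available explains this result.

On these data alone, whether a group carrying an amine or a carboxylic acid at this position would give a similar number remains open. Compound 1 differs from compound 2 in more than one place, so the separate contributions of the chain and the aromatic group also remain unresolved.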